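The source may report more compounds than this note shows. Statements on the series, on what has been measured and on what is new or still open speak of the compounds shown alone.

Measured so far:
- compound 1, `Oc1ccc(-c2cc(-c3ccccc3F)cc(-c3cccc(O)c3)n2)cc1`: 6370 nM
- compound 2, `Oc1ccc(-c2cc(-c3cccc(F)c3)cc(-c3cccc(O)c3)n2)cc1`: 3510 nM
- compound 3, `Oc1ccc(-c2cc(-c3ccccc3C(F)(F)F)cc(-c3ccccc3O)n2)cc1`: 7180 nM

All three were tested in a functional assay on T47D cells (Homo sapiens) for inhibition; a higher number here means a weaker inhibitor, a lower number a stronger inhibitor. Compound 3 gives the highest number of the three; compound 1 lies within the scatter of it, while compound 2 is the one furthest from it, a gap just beyond the scatter. Within the data shown here, the only measured step, a 1.8-fold lower number from compound 1 to compound 2 (0.26 log units; within the scatter), concerns a shift of fluorine on a different ring and stays within the scatter.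

Compound 4, `Oc1ccc(-c2cc(-c3ccccc3C(F)(F)F)cc(-c3cccc(O)c3)n2)cc1`, differs from compound 3 by 3-hydroxyphenyl in place of 2-hydroxyphenyl on an aromatic carbon. Among the measured compounds shown here, no measured pair shows this change, so the nearest guide is that compound 1 and compound 2, which both carry a 3-hydroxyphenyl group, give numbers close to that of compound 3. The step from compound 3 to compound 4 is therefore expected to be small, a 1.3-fold lower number from compound 3 to compound 4 (0.12 log units; within the scatter), most likely within the scatter. Compound 4 is estimated at 5500 nM, with a likely range from 2000 nM to 15000 nM.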

Compound 4, half-maximal inhibitory concentration: 3210 nM
For compound 4 the middle estimate is 1.7-fold (0.23 log units) above the measured one; the measured number falls inside the stated range.
By their numbers in this assay, from the lowest: compounds 4, 2, 1 and 3 (each within the scatter of the next, the first and the last beyond it).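

In this assay, among these compounds, 3-hydroxyphenyl in place of 2-hydroxyphenyl next to the ring nitrogen gives a 2.2-fold lower number from compound 3 to compound 4 (0.35 log units; beyond the scatter) and is the first single change in this set to clear the scatter, though only modestly. With 3-hydroxyphenyl kept in that place, the group on the other side can differ with little effect: trifluoromethyl in place of fluoro gives a 2.0-fold lower number from compound 1 to compound 4 (0.30 log units; within the scatter) and 2-(trifluoromethyl)phenyl in place of 3-fluorophenyl gives a 1.1-fold lower number from compound 2 to compound 4 (0.04 log units; within the scatter) and both steps stay within the scatter. The hydroxyl shift rests on one pair of compounds, and nothing here offers an explanation for it.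

From the compounds shown here alone, whether the same shift holds when the other group is 2-fluorophenyl or 3-fluorophenyl remains open. Also open, going by these compounds, is how a methoxyphenyl or an aminophenyl group would compare with 3-hydroxyphenyl at this position.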